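The compounds below may be only part of what the source reports. "The series", "measured", "known", "first", "only" and "open" are said of these compounds alone.

Measured so far in an ADME assay on microsomes from liver (Homo sapiens) for metabolic stability; on this read-out higher numbers stand for a longer-lived compound and lower numbers for a shorter-lived compound:
- compound 1, `CC(C)C(Nc1nccs1)c1ccc(-c2ccc3cccc(F)c3c2)[nH]c1=O`: 0.17 h
- compound 2, `CC(C)[C@@H](C[C@H]1CCNC1=O)c1ccc(-c2ccc3cccc(F)c3c2)[nH]c1=O`: 0.693 h

Compound 1 holds the lowest of the two numbers measured in this assay. The nearest measured neighbour is compound 2, whose number in this assay stands higher by a margin that lies beyond the usual scatter. Within the data shown here, no pair of measured compounds differs in a single place, so no measured step is available to guide the next change directly.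

Compound 3, `Cc1c[nH]c(C(c2ccc(-c3ccc4cccc(F)c4c3)[nH]c2=O)C(C)C)n1`, has not yet been measured in this assay. It differs from compound 1 in one place:

4-methyl-1H-imidazol-2-yl in place of (1,3-thiazol-2-yl)amino on a saturated chain carbon bound to an aromatic carbon and a saturated chain carbon

The shared core and the branched side chain are kept; only the group on the saturated chain carbon is exchanged. Among the measured compounds shown here, with no measured step of this kind to lean on, the expectation for compound 3 rests on compound 1 alone, and the step from compound 1 to compound 3 is expected to be small, upward if anything, and likely within or only just beyond the scatter, as a 1.5-fold higher number from compound 1 to compound 3 (0.17 log units; within the scatter) expresses. Compound 3 is therefore estimated at 0.25 h in this assay, with an expected range from 0.1 h to 0.7 h.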

Compound 3, half-life: 0.09 h
Compound 3: the middle estimate sits 2.8-fold (0.44 log units) above what was measured; the whole stated range lies above it.
By their numbers in this assay, from the lowest: compounds 3 and 1 (each within the scatter of the next); then compound 2.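

On the saturated chain carbon bound to an aromatic carbon and a saturated chain carbon, the exchange of (1,3-thiazol-2-yl)amino for 4-methyl-1H-imidazol-2-yl gives, in this assay, a 1.9-fold lower number from compound 1 to compound 3 (0.28 log units; within the scatter), so this exchange does not separate the two groups on this read-out. Among these compounds, the two groups match in heavy-atom count and in hydrogen-bond donor count, and each holds one five-membered aromatic ring with 2 hetero atoms, but they differ in sulfur content, in the hydrogen-bond acceptor count and in the attachment through the amino nitrogen; none of these differences produces a step beyond the usual scatter here, which is the first direct reading at this position. Nothing available explains how either group relates to the half-life at this position.

Open, as far as these compounds go, is whether a group of another kind on this carbon, such as a morpholine, a primary amine or a carboxylic acid, would give a step beyond the scatter in this assay when set against compound 1. Also open, from the compounds shown here alone, is whether a change elsewhere, such as a cyclopropyl group in place of the branched side chain, would do so with the rest of compound 1 kept.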